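Compound 2 to compound 4: a ring group swap

A few compounds are considered here, and "the series" means these few. Any claim that something is new, unique, unknown or untested is made for them only; others in the source may bear on it.

Values in an ADME assay on KB cells (Homo sapiens) for cytotoxicity, with a stated time of 48 h (a lower number here means a stronger inhibitor, a higher number a weaker inhibitor), are as follows
- compound 1 `C=C1[C@H](C)CCC[C@]1(C)CC/C(C)=C/CC1=C(O)C(=O)C=C(N[C@@H](C(=O)O)C(C)C)C1=O` gives 6.2 ug/mL as a number
- compound 2 `CC1=CCC[C@](C)(CC/C(C)=C/CC2=C(O)C(=O)C=C(N[C@@H](CO)C(=O)O)C2=O)[C@@H]1C` gives > 10 ug/mL as a limit
- compound 3 `CC1=CCC[C@](C)(CC/C(C)=C/CC2=C(O)C(=O)C=C(N[C@H](CO)C(=O)O)C2=O)[C@@H]1C` gives > 10 ug/mL as a limit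

Compound 2 thus has no number to start from, only a limit. Going to compound 4 `C=C1[C@H](C)CCC[C@]1(C)CC/C(C)=C/CC1=C(O)C(=O)C=C(N[C@@H](CO)C(=O)O)C1=O` is the change a group of 9 heavy atoms (9 carbon; one six-membered non-aromatic ring of carbon only) in place of a group of 9 heavy atoms (9 carbon; one six-membered non-aromatic ring of carbon only), on a saturated chain carbon, two bonds along the chain from a double-bonded chain carbon with the atoms joined differently. Among the compounds with values here, the one measured step, a step that the two limits leave unreadable from compound 2 to compound 3, concerns configuration only and offers no size to carry over. The entering group also stands in compound 1, which gives 6.2 ug/mL but differs elsewhere too. No step beyond the scatter is expected in this assay and no direction can be read, so the estimated step is a step that the limit leaves unreadable from compound 2 to compound 4 for now. Compound 4 is expected at 12 ug/mL within 6 ug/mL to 25 ug/mL and may report only a limit.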

Compound 4, half-maximal inhibitory concentration: > 10 ug/mL
Compound 4 gave a limit, no number; the forecaster's own chance of this, stated with the estimate: 60%; the middle value does not contradict the limit.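

In this assay compound 4 gives > 10 ug/mL, which is a limit and not a number. The swap of the 1,2,3-trimethylcyclohex-3-en-1-yl group on this saturated chain carbon therefore cannot be read, like the other steps between limits: the limit of > 10 ug/mL in this assay, at which 3 of the 4 values shown sit. Within the data shown here, on the amine nitrogen, 1-carboxy-2-hydroxyethyl in place of 1-carboxy-2-methylpropyl gives the one readable comparison, an at least 1.6-fold higher number from compound 1 to compound 4 (0.20 log units; that floor lies within the scatter).

From the compounds shown here alone, whether the two ring groups differ at all, and the true size of the amine-nitrogen step, remain open. So does the outcome with an aminoalkyl chain in place of 1-carboxy-2-hydroxyethyl on that nitrogen.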